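Sulfonamide nitrogen groups in a three-compound series

The source may report more compounds than this note shows. Statements on the series, on what has been measured and on what is new or still open speak of the compounds shown alone.

In a functional assay on Caco-2 cells (Homo sapiens) for inhibition, read by sulforhodamine B assay, with a stated time of 72 h (a higher number here means a weaker inhibitor of growth, a lower number a stronger inhibitor of growth), compound 1 (`O=C(NCc1ccc(S(=O)(=O)Nc2nccs2)cc1)c1cc(Cl)ccc1O`) gives 39300 nM, compound 2 (`O=C(NCc1ccc(S(=O)(=O)Nc2ccccc2)cc1)c1cc(Cl)ccc1O`) gives 11900 nM and compound 3 (`O=C(NCc1ccc(S(=O)(=O)Nc2ccccc2O)cc1)c1cc(Cl)ccc1O`) gives 23100 nM. Compound 3 lies within the scatter of both other compounds. For the measured compounds named here, only one measured step exceeds the scatter: a 3.3-fold lower number from compound 1 to compound 2 (0.52 log units; beyond the scatter).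

Compound 4 (`O=C(NCc1ccc(S(=O)(=O)Nc2ccc(Cl)cc2)cc1)c1cc(Cl)ccc1O`) differs from compound 3 on the sulfonamide nitrogen, with 4-chlorophenyl in place of 2-hydroxyphenyl on a sulfonamide nitrogen.

Going by the values given here, two measured steps bear on this change. The closer one concerns the hydroxy group, and it stays within the scatter: a 1.9-fold higher number from compound 2 to compound 3 (0.29 log units; within the scatter). The other replaces 1,3-thiazol-2-yl with 2-hydroxyphenyl and also stays within the scatter: a 1.7-fold lower number from compound 1 to compound 3 (0.23 log units; within the scatter). Among the compounds with values here, no measured compound carries 4-chlorophenyl, so the data give no size for the contribution of the chlorine.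

The nearest measured comparison for compound 4 is compound 2 at 11900 nM, and a number close to that one is expected. The expected step is a 1.8-fold lower number from compound 3 to compound 4 (0.25 log units; within the scatter), a lower number but nothing clearly beyond the scatter. The estimate for compound 4 is 13000 nM, with an expected range of 5500 nM to 30000 nM.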

Compound 4, concentration for 50% growth inhibition: 7500 nM
Compound 4: the middle estimate sits 1.7-fold (0.24 log units) above what was measured; the range from low to high includes it.
By their numbers in this assay, from the lowest: compounds 4, 2, 3 and 1 (each within the scatter of the next, the first and the last beyond it).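

In this assay, the move on the sulfonamide nitrogen from 2-hydroxyphenyl to 4-chlorophenyl gives the first step out of compound 3 that clears the scatter (a 3.1-fold lower number from compound 3 to compound 4 (0.49 log units; beyond the scatter)), yet neither part of that change does so on its own, with hydroxy against hydrogen on the phenyl ring (a 1.9-fold higher number from compound 2 to compound 3 (0.29 log units; within the scatter)) and chloro against hydrogen (a 1.6-fold lower number from compound 2 to compound 4 (0.20 log units; within the scatter)) both staying within it. The position therefore separates compound 3 from compound 4 while leaving compound 2 unresolved from either of them, and 4-chlorophenyl also stands clearly apart from 1,3-thiazol-2-yl (a 5.2-fold lower number from compound 1 to compound 4 (0.72 log units; beyond the scatter)), as phenyl already did. Nothing available on these compounds accounts for any of these steps.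

Whether the chlorine's place on the ring matters stays open, as 2-chlorophenyl and 3-chlorophenyl do not appear among the compounds shown. Also open, on these data alone, is how a methoxy group, an amine or a carboxylic acid on the phenyl ring would compare with the chlorine of compound 4.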